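Changing the amide side group of compound 2

The source may report more compounds than this note shows. Statements on the series, on what has been measured and on what is new or still open speak of the compounds shown alone.

Among the measured compounds shown here, in a functional assay on PC-3 cells (Homo sapiens) for antiproliferative activity, read by MTT assay, with a stated time of 24 h (on this read-out higher numbers stand for weaker inhibition and lower numbers for stronger inhibition), compound 2 `CCn1c(C(=O)N[C@H](CO)CCCO)ccc1C(CC)(CC)c1ccc(OCS(=O)(=O)c2ccccc2)c(C)c1` gives 6810 nM, the only actual number so far. For the measured compounds named here, its one measured neighbour, compound 1 `CCn1c(C(=O)NCC(=O)OC)ccc1C(CC)(CC)c1ccc(OCS(=O)(=O)c2ccccc2)c(C)c1`, gives > 50000 nM. That value is a limit of the assay and not a number.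

The next compound, compound 3 `CCn1c(C(=O)NCCC(=O)O)ccc1C(CC)(CC)c1ccc(OCS(=O)(=O)c2ccccc2)c(C)c1`, keeps the shared core and changes one group: a group of 5 heavy atoms (3 carbon, 2 oxygen; no ring) in place of a group of 7 heavy atoms (5 carbon, 2 oxygen; no ring), on an amide-type nitrogen. The group that enters is 2-carboxyethyl, which has the same heavy-atom count as the group in compound 1, although the two are different groups.

Going by the values given here, only one measured step bears on this change, and it sits at the same amide-type nitrogen: an at least 7.3-fold lower number from compound 1 to compound 2 (0.86 log units; beyond the scatter). Going from compound 2 to compound 3 shortens the group again, so with that step of compound 1 as the only guide, part of it is expected to be reversed in this assay. One step is thin support, so the expectation is loose. The expected change is a 2.9-fold higher number from compound 2 to compound 3 (0.47 log units; beyond the scatter). For compound 3 the estimated value is 20000 nM, with an expected range from 7000 nM to 50000 nM.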

Compound 3, half-maximal inhibitory concentration: 14400 nM
For compound 3 the middle estimate is 1.4-fold (0.14 log units) above the measured one; low and high end bracket the measured number.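

The amide-type nitrogen now has its first step in this assay with an actual number at both ends, a 2.1-fold higher number from compound 2 to compound 3 (0.33 log units; beyond the scatter). The change from the larger group with its defined stereocentre to the shorter 2-carboxyethyl therefore has a measured size, and that size is modest. The other step, an at least 3.4-fold lower number from compound 1 to compound 3 (0.54 log units; beyond the scatter), joins two groups of the same heavy-atom count, carboxymethyl in place of methoxycarbonyl on a saturated chain carbon bound to an amide-type nitrogen, so among these compounds heavy-atom count alone does not set the number, and the true size of this step stays unknown because the value of compound 1 is a limit of the assay and not a number: the limit of > 50000 nM in this assay, at which 1 of the 3 values shown sits.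

Compound 2 and compound 3 differ in both chain and chain ends at once, so the compounds shown cannot separate the effect of one from the other. On these data alone, how an amine at the chain end, or a phenyl ring on the chain, would read in this assay also stays open, as does whether any group at this nitrogen can bring the number far below that of compound 2.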